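The source may hold more compounds than are shown below. What is called first, only, known or untested is meant among the compounds shown, and "the series" means these compounds.

In a functional assay on T47D cells (Homo sapiens) for inhibition, read by CCK-8 assay, with a stated time of 72 h, tested at 10 uM (on this read-out higher numbers stand for more inhibition of growth at the one concentration tested and lower numbers for less inhibition of growth), compound 3 (`COc1ccc(NC(=O)C2(C(=O)Nc3ccc(Nc4ncc5cc(C(=O)N(C)C)n(C6CCCC6)c5n4)cc3)CC2)cc1`) gives 96.1%. Compound 1 (`CN(C)C(=O)c1cc2cnc(Nc3ccc(NC(=O)C4(C(=O)Nc5ccc(Cl)cc5)CC4)cc3)nc2n1C1CCCC1`) gives 95%. The measured step is a number 1.1 percentage points higher from compound 1 to compound 3 (within the scatter), so these two cannot be separated on this read-out. Compound 2 (`CN(C)C(=O)c1cc2cnc(Nc3ccc(NC(=O)C4(C(=O)Nc5cccc(O)c5)CC4)cc3)nc2n1C1CCCC1`) gives 83.7%, and the step here is a number 12.4 percentage points higher from compound 2 to compound 3 (beyond the scatter), which places compound 3 clearly ahead of compound 2.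

Compound 4 (`CN(C)C(=O)c1cc2cnc(Nc3ccc(NC(=O)C4(C(=O)Nc5ccccc5F)CC4)cc3)nc2n1C1CCCC1`) keeps the shared core of compound 3 and alters one group, with 2-fluorophenyl in place of 4-methoxyphenyl on an amide-type nitrogen. Among the compounds with values here, none of the measured compounds carries 2-fluorophenyl, so no step gives a direct precedent. The closest evidence comes from the three exchanges of the aromatic group at this same nitrogen. Two of them are modest, namely a number 11.3 percentage points lower from compound 1 to compound 2 (beyond the scatter) and a number 12.4 percentage points higher from compound 2 to compound 3 (beyond the scatter), and the third is the step from compound 1 to compound 3 already shown to lie within the scatter. Compound 2 is the only one of the three set apart from the others. A large loss therefore seems unlikely, although a modest one cannot be excluded. The expected change is a number 6.1 percentage points lower from compound 3 to compound 4 (within the scatter). For compound 4 the estimated value is 90%, with an expected range from 76% to 99%.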

Compound 4, percent growth inhibition at one concentration: 97.8%
Estimate against measurement, compound 4: 7.8 percentage points below; the measured number falls inside the stated range.
By their numbers in this assay, from the lowest: compound 2; then compounds 1, 3 and 4 (each within the scatter of the next).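

In this assay, the step to a fluorine-bearing aromatic group at this amide-type nitrogen is read as a number 1.7 percentage points higher from compound 3 to compound 4 (within the scatter) and, against the 4-chlorophenyl group, as a number 2.8 percentage points higher from compound 1 to compound 4 (within the scatter) so the exchange of a para-free... 

Correction, final text:

In this assay, replacing 4-methoxyphenyl with 2-fluorophenyl on the amide-type nitrogen gives a number 1.7 percentage points higher from compound 3 to compound 4 (within the scatter) and replacing 4-chlorophenyl with the same group gives a number 2.8 percentage points higher from compound 1 to compound 4 (within the scatter) so a third aromatic group at this nitrogen, now one carrying fluorine, cannot be separated from the other two on this read-out. Only the 3-hydroxyphenyl group of compound 2 stays apart, with a number 14.1 percentage points higher from compound 2 to compound 4 (beyond the scatter) and this shows that the lower number of compound 2 is not shared by the 2-fluorophenyl group, leaving compound 2 as the single exception among the four compounds. Nothing available here bears on why compound 2 differs from the others.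

The compounds shown leave open how a phenyl group carrying an amine or a carboxylic acid, or a saturated group such as cyclohexyl, would behave on this nitrogen. They also leave open whether compounds 1, 3 and 4 differ at all, since a growth inhibition read at one concentration does not separate them.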